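A Triazole Hydroxamate Series and an Isoquinoline Analogue

The compounds below may be only part of what the source reports. "The series", "measured", "known", "first", "only" and "open" are said of these compounds alone.

Compound 1 `O=C(O)c1ccc(NCc2nc(-c3ccccc3)nn2-c2ccccc2)cc1`: -0.4%
Compound 2 `O=C(NO)c1ccc(NCc2nc(-c3ccc(Br)o3)nn2-c2ccccc2)cc1`: 55.8%
Compound 3 `O=C(NO)c1ccc(NCc2nc(-c3ccccc3)nn2-c2ccc(Br)cc2)cc1`: 65.9%

All three numbers come from an assay on Sf9 cells for inhibition of protein deacetylase HDAC6 (Homo sapiens), read by fluorescence, with a stated time of 40 min, tested at 100 nM; on this read-out higher numbers stand for more inhibition at the one concentration tested (going by the name of the read-out) and lower numbers for less inhibition. Compound 2 stands second highest of the three: its nearest neighbour, compound 3, lies higher by a gap beyond the usual scatter, while the furthest, compound 1, lies far lower, also beyond the scatter. Compound 1 carries a carboxylic acid where compounds 2 and 3 carry a hydroxamic acid, and only compound 1 shows essentially no inhibition.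

The unmeasured compound 4 `O=C(NO)c1ccc(NCc2nc(-c3cccc4cnccc34)nn2-c2ccccc2)cc1` keeps the hydroxamic acid and the phenyl on the ring nitrogen of compound 2 and differs from it in one place: isoquinolin-5-yl in place of 5-bromofuran-2-yl on an aromatic carbon. For the measured compounds named here, no measured pair isolates an aryl swap of this kind, so the step in this assay is expected to be small, in no clear direction, because compound 2 at 55.8% and compound 3 at 65.9% already lie in one region. Compound 4 is therefore expected to give 58%, between 35% and 78%. The expected step of a number 2.2 percentage points higher from compound 2 to compound 4 (within the scatter) is estimated to stay within the scatter.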

Compound 4, a percentage reported as inhibition, at one concentration (the size of the read-out at that concentration, not a potency): 40.2%
Compound 4: middle estimate off by 17.8 percentage points, on the high side; the measured number falls inside the stated range.
By their numbers in this assay, from the lowest: compound 1; then compound 4; then compound 2; then compound 3.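

In this assay, for the compounds shown here, isoquinolin-5-yl in place of 5-bromofuran-2-yl gives a number 15.6 percentage points lower from compound 2 to compound 4 (beyond the scatter), the first single-place step at this aromatic carbon, and it shows that the number responds to the group held there. With the hydroxamic acid and the phenyl on the ring nitrogen kept, compound 4 gives 40.2% while carrying two six-membered aromatic rings at this carbon. Nothing shown here bears on why the number moves.

Going by these compounds, this single swap changes the ring, its size and the bromine all at once, so the share of each in the step stays open. On these data alone, how furan-2-yl without the bromine, or naphthalen-1-yl without the ring nitrogen of the isoquinoline, would behave at this carbon also remains open.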